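The compounds below may be only part of what the source reports. "The series", "measured", "known", "first", "only" and "open" are said of these compounds alone.

Compound 2 `Cc1nn(-c2ccccc2I)c2c1C(c1ccc(Oc3ccccc3)cc1)SC(C)C(=O)N2` gives 1300 nM in an assay on isolated protein for agonist activity at Bile acid receptor (Homo sapiens), read by AlphaScreen, with a stated time of 30 min (a lower number here means that less compound is needed, a higher number that more compound is needed for the effect), the higher of the two numbers in hand, though the gap to compound 1 lies within the scatter. Compound 1 `CCc1ccccc1-n1nc(C)c2c1NC(=O)[C@H](C)S[C@@H]2c1ccc(Oc2ccccc2)cc1` gives 1100 nM in this assay. Compound 3 `Cc1nn(-c2ccccc2Br)c2c1C(c1ccc(Oc3ccccc3)cc1)SC(C)C(=O)N2` differs from compound 2 by bromo in place of iodo on an aromatic carbon. Going by the values given here, no step between measured compounds shows this exchange; it is expected to move this assay little, in no set direction, and not beyond the scatter. For compound 3 the estimate is 1300 nM, with a range of 600 nM to 2800 nM. The expected step of no change at the digits printed from compound 2 to compound 3 (within the scatter) is accordingly small.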

Compound 3, half-maximal effective concentration: 1800 nM
Beside the measured number, compound 3's estimate is 1.4-fold (0.14 log units) below it; measured number inside the range.
By their numbers in this assay, from the lowest: compounds 1, 2 and 3 (each within the scatter of the next).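

Going from iodo to bromo on this aromatic carbon, ortho to a large group, gives a 1.4-fold higher number from compound 2 to compound 3 (0.14 log units; within the scatter) in this assay. The 2-iodophenyl and 2-bromophenyl compounds therefore cannot be told apart in this assay, so this exchange of one halogen for the other has no readable effect here. Nothing in hand explains this result. Open, on these data alone, is what a fluoro, a methoxy or an amine at this place would give. Also open, as far as these compounds go, is whether the same exchange stays as small when another part of the shared core changes.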